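The source may report more compounds than this note shows. Statements on the series, on what has been measured and on what is new or still open speak of the compounds shown alone.

Compound 3 `N#CC1=C(N)Oc2c(N)cc3nc4ccccc4nc3c2C12C(=O)N(Cc1cnnn1-c1ccccc1Br)c1ccccc12` gives 27400 nM in a functional assay on A549 cells (Homo sapiens) for antiproliferative activity, read by MTT assay, with a stated time of 48 h; on this read-out higher numbers stand for weaker inhibition and lower numbers for stronger inhibition. Of the two numbers measured, this is the lower one; compound 2 `N#CC1=C(N)Oc2c(c3nc4ccccc4nc3c3ccccc23)C12C(=O)N(Cc1cnnn1-c1cccc(S(N)(=O)=O)c1)c1ccccc12` gives 44200 nM, a gap that sits within the scatter. Compound 1 `N#CC1=C(N)Oc2c(c3nc4ccccc4nc3c3ccccc23)C12C(=O)N(Cc1cnnn1-c1ccccc1Br)c1ccccc12` gives > 50000 nM, which is a limit of this assay rather than a number. Compound 4 `CCc1cccc(C)c1-n1nncc1CN1C(=O)C2(C(C#N)=C(N)Oc3c(N)cc4nc5ccccc5nc4c32)c2ccccc21` differs from compound 3 in one place: 2-ethyl-6-methylphenyl in place of 2-bromophenyl on an aromatic nitrogen. Among the compounds with values here, only one measured step touches the same position, an at least 1.1-fold lower number from compound 1 to compound 2 (0.05 log units; that floor lies within the scatter), and it lies within the scatter, so exchanging one ring on that aromatic nitrogen for another has not yet produced a clear shift. For compound 4 no step beyond the scatter is therefore expected, a 1.0-fold lower number from compound 3 to compound 4 (0.01 log units; within the scatter). Compound 4 is estimated at 27000 nM, between 10000 nM and 70000 nM.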

Compound 4, half-maximal inhibitory concentration: > 50000 nM
Compound 4 gave a limit, no number; the forecaster's own chance of this, stated with the estimate: 25%; middle value at least 1.8-fold (0.26 log units) from the limit.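

Compound 4 gives > 50000 nM, which is a limit and not a number. Placing 2-ethyl-6-methylphenyl on the aromatic nitrogen gives an at least 1.8-fold higher number from compound 3 to compound 4 (0.26 log units; that floor lies within the scatter), so this change starts from a measured value yet still shows no shift clearly beyond the scatter. The true size of the step cannot be read because the result stops at a limit: the limit of > 50000 nM in this assay, at which 2 of the 4 values shown sit.

As far as these compounds go, whether a ring carrying an amine or a carboxylic acid at this position would give a clearly lower number than compound 3 remains open.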